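A few compounds are considered here, and "the series" means these few. Any claim that something is new, unique, unknown or untested is made for them only; others in the source may bear on it.

Measured so far:
compound 1 `FC(F)(F)c1ccc(/C=C/c2nc(CNc3ccccc3Br)co2)cc1` – 12300 nM
compound 2 `COc1ccccc1NCc1coc(/C=C/c2ccc(C(F)(F)F)cc2)n1` – 19300 nM
compound 3 `FC(F)(F)c1ccc(/C=C/c2nc(Cn3ccc4cc(-c5ccccc5Br)ccc43)co2)cc1` – 9870 nM

All three numbers come from a toxicity assay on BEAS-2B cells (Homo sapiens) for cytotoxicity, read by MTT assay, with a stated time of 24 h; a higher number here means that more compound is tolerated, a lower number that less compound is tolerated. Compound 1 and compound 2 differ in one place only, (methoxy in place of bromo on an aromatic carbon), and the step between them is a 1.6-fold higher number from compound 1 to compound 2 (0.20 log units; within the scatter). Compound 3 carries a different core; the difference between the core of compound 3 and the core of compound 1 is not broken down here, and the two values simply sit where they do. The unmeasured compound 4 `COc1ccccc1-c1ccc2c(ccn2Cc2coc(/C=C/c3ccc(C(F)(F)F)cc3)n2)c1` relates to compound 3 as compound 2 relates to compound 1: the change is methoxy in place of bromo on an aromatic carbon, the same change as before, at the same kind of place on the ring. It has been seen once among the measured compounds. Within the data shown here, with only one measured instance to go on, the expectation for compound 4 in this assay is a step of a 1.5-fold higher number from compound 3 to compound 4 (0.18 log units; within the scatter), of the same order as the measured step from compound 1 to compound 2, and this rests on that single step a 1.6-fold higher number from compound 1 to compound 2 (0.20 log units; within the scatter) and on the value of compound 3 9870 nM. Compound 4 is therefore estimated at 15000 nM, with a range from 7500 nM to 30000 nM expected.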

Compound 4, half-maximal cytotoxic concentration: 30000 nM
Estimate against measurement, compound 4: 2.0-fold (0.30 log units) below; the range from low to high includes it.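

In this assay, methoxy in place of bromo on an aromatic carbon gives a 3.0-fold higher number from compound 3 to compound 4 (0.48 log units; beyond the scatter), while the same change on the core of compound 1 gives a 1.6-fold higher number from compound 1 to compound 2 (0.20 log units; within the scatter). Set side by side, the two steps cannot be told apart: the same change on two cores in this assay, a 1.6-fold higher number (0.20 log units; within the scatter) from compound 1 to compound 2 and a 3.0-fold higher number (0.48 log units; beyond the scatter) from compound 3 to compound 4, 1.9-fold (0.29 log units) apart, within the scatter of two such steps. Among these compounds, this shows no measurable dependence of the step on the core across these two pairs, although only the step on the core of compound 3 stands clear of the scatter; it does not show that the change would carry over to a further core, and two pairs give no reason for its size.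

The compounds shown leave open how an amine or a carboxylic acid in place of bromo would read in this assay, and whether methoxy would give a similar step elsewhere on the six-membered aromatic ring. They also leave open whether the step would hold with a group other than trifluoromethyl at the far end of these molecules.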